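This account rests on a few compounds, and the source may have more. Where it says the series, first, only, none or still open, it means among the compounds named here.

Among the compounds with values here, compound 1 `COc1cc(CC(C)C(=O)N2CCN(c3ccc(C(F)(F)F)cc3[C@@H](N)CC(C)C)CC2)ccc1Cl` is one of two compounds measured in an assay on HEK293 cells for displacement of a labelled ligand from Melanocortin receptor 4 (Homo sapiens); a higher number here means a weaker inhibitor, a lower number a stronger inhibitor. In this assay compound 1 gives 230 nM, the higher of the two numbers recorded, while compound 2 `CC(C)C[C@H](N)c1cc(C(F)(F)F)ccc1N1CCN(C(=O)C(C)Cc2ccc(Cl)cc2O)CC1` gives 36 nM. Within the data shown here, the only step on record is a 6.4-fold lower number from compound 1 to compound 2 (0.81 log units; beyond the scatter), where 4-chloro-2-hydroxyphenyl takes the place of 4-chloro-3-methoxyphenyl on the saturated chain carbon two bonds from the carbonyl carbon.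

Compound 3 `CC(C)C[C@H](N)c1cc(C(F)(F)F)ccc1N1CCN(C(=O)COc2ccc(O)cc2)CC1` has not yet been tested. Relative to compound 1 the change is (4-hydroxyphenoxy)methyl in place of 1-(4-chloro-3-methoxybenzyl)ethyl on a carbonyl carbon. This reaches further than the step from compound 1 to compound 2: the aromatic ring changes its substitution and the linking chain to the carbonyl carbon is rebuilt as well. Among the measured compounds shown here, only the single step above bears on it, and it does so loosely, since it shows that a hydroxyl-bearing ring can be accompanied by a lower number, but it says nothing about the altered chain or the loss of the chlorine. Compound 3 is therefore expected to give roughly 300 nM, within 60 nM to 1500 nM, a step of about a 1.3-fold higher number from compound 1 to compound 3 (0.12 log units; within the scatter) that is estimated with wide uncertainty.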

Compound 3, inhibition constant: 4600 nM
Compound 3: middle estimate off by 15-fold (1.19 log units), on the low side, and the stated range ends below it.
By their numbers in this assay, from the lowest: compound 2; then compound 1; then compound 3.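

At the carbonyl carbon whose other neighbour is the amide-type nitrogen in a ring, the group proves far more consequential than the first pair alone could show: putting (4-hydroxyphenoxy)methyl in place of 1-(4-chloro-3-methoxybenzyl)ethyl gives a 20-fold higher number from compound 1 to compound 3 (1.30 log units; beyond the scatter) in this assay and is a large loss of binding. Set against 1-(4-chloro-2-hydroxybenzyl)ethyl, the same group gives a 130-fold higher number from compound 2 to compound 3 (2.11 log units; beyond the scatter) as a still larger step, so a hydroxyl on the aromatic ring does not by itself go with a low number: compound 2 and compound 3 both carry one, yet they hold the lowest and highest of the three numbers. Nothing available accounts for either step.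

The replacement alters the chlorine, the ring's other substituent and the chain together, so these compounds cannot show how much of the loss belongs to each. Also open, from the compounds shown here alone, is whether a longer chain to the ring, or an amine in the chain in place of its oxygen, would bring the number back toward that of compound 2 or compound 1.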